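A chloro added at another aryl of the thiazolyl ketone series

This account rests on a few compounds, and the source may have more. Where it says the series, first, only, none or still open, it means among the compounds named here.

Compound 2 `Cc1nc(-c2ccccc2)sc1C(=O)CSc1nc(-c2ccccc2)c(C#N)c(=O)[nH]1` is the parent of this small set, and in a functional assay on U-87MG ATCC cells for antiproliferative activity against U-87 MG (Homo sapiens), read by MTT assay, with a stated time of 48 h (a higher number here means a weaker inhibitor, a lower number a stronger inhibitor), compound 2 gives 56600 nM, the highest of the three numbers shown. Its nearest neighbour is compound 3 `Cc1nc(-c2ccc(Cl)cc2)sc1C(=O)CSc1nc(-c2ccccc2)c(C#N)c(=O)[nH]1`, which in this assay gives 27600 nM; the step is a 2.1-fold lower number from compound 2 to compound 3 (0.31 log units; beyond the scatter). For the measured compounds named here, compound 1 `COc1ccc(-c2nc(C)c(C(=O)CSc3nc(-c4ccc(OC)cc4)c(C#N)c(=O)[nH]3)s2)cc1`, bearing two methoxy groups, gives 25300 nM in this assay, and no single-point step connects it to compound 2.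

Compound 4 `Cc1nc(-c2ccccc2)sc1C(=O)CSc1nc(-c2cccc(Cl)c2)c(C#N)c(=O)[nH]1` differs from compound 2 by chloro in place of hydrogen on an aromatic carbon; the same difference, taken one bond further out, reads phenyl to 3-chlorophenyl. Going by the values given here, the only measured step that bears on it is the chloro addition from compound 2 to compound 3, which lowered the number modestly, though on a different aryl ring. Assuming a similar but uncertain effect, compound 4 is expected to show a 1.6-fold lower number from compound 2 to compound 4 (0.21 log units; within the scatter), and its estimated value in this assay is 35000 nM, within a range of 18000 nM to 70000 nM.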

Compound 4, half-maximal inhibitory concentration: 28200 nM
Compound 4: middle estimate off by 1.2-fold (0.09 log units), on the high side; measured number inside the range.
By their numbers in this assay, from the lowest: compounds 1, 3, 4 and 2 (each within the scatter of the next, the first and the last beyond it).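

For the compounds shown here, compound 4 gives the first reading of a chloro on the other phenyl ring of the series, where the change from phenyl to 3-chlorophenyl in this assay gives a 2.0-fold lower number from compound 2 to compound 4 (0.30 log units; within the scatter). This step lies within the scatter, so it cannot show that chloro at this place changes the number, whereas the chloro on the phenyl carried by the thiazole gave a 2.1-fold lower number from compound 2 to compound 3 (0.31 log units; beyond the scatter), which lies beyond it. Nothing available offers an explanation for the reading at this position.

The compounds shown leave open whether an amine or a carboxylic acid in place of the chloro would give a step beyond the scatter. They also leave open what chloro groups on both phenyl rings of one molecule would give.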